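This account rests on a few compounds, and the source may have more. Where it says the series, first, only, none or still open, it means among the compounds named here.

The measured compounds:

Compound 1 `COc1cc(N(Cc2ccc(F)cc2)C(=O)CSc2nc3ccccc3s2)cc(OC)c1OC` gives 59800 nM in a functional assay on HCT-116 cells (Homo sapiens) for antiproliferative activity, read by MTT assay, with a stated time of 48 h; a lower number here means a stronger inhibitor, a higher number a weaker inhibitor.
Compound 2 `COc1cc(N(Cc2ccc(Br)cc2)C(=O)CSc2nc3ccccc3s2)cc(OC)c1OC` gives 63800 nM.
Compound 3 `COc1ccc(CN(C(=O)CSc2nc3ccccc3s2)c2cc(OC)c(OC)c(OC)c2)cc1OC` gives 33900 nM.

Compound 1 holds the second highest of the three numbers in this assay. Its nearest neighbour is compound 2, reached by a 1.1-fold higher number from compound 1 to compound 2 (0.03 log units; within the scatter), and its furthest is compound 3, reached by a 1.8-fold lower number from compound 1 to compound 3 (0.25 log units; within the scatter); both steps stay within the scatter, so the three compounds cannot be separated on these data.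

The unmeasured compound 4 `COc1cc(N(Cc2ccc(Cl)cc2)C(=O)CSc2nc3ccccc3s2)cc(OC)c1OC` differs from compound 1 in one place: chloro in place of fluoro on an aromatic carbon. Going by the values given here, the only measured step that bears on it is the one from fluoro to bromo on the same aromatic carbon, a 1.1-fold higher number from compound 1 to compound 2 (0.03 log units; within the scatter), which did not move the number beyond the scatter. Since chloro sits between fluoro and bromo in that series and the bromo step was flat, no step beyond the scatter is expected for compound 4 in this assay. Compound 4 is therefore expected to give about 60000 nM, within 30000 nM to 120000 nM, a step of a 1.0-fold higher number from compound 1 to compound 4 (0.00 log units; within the scatter) that is expected to lie within the scatter.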

Compound 4, half-maximal inhibitory concentration: 603000 nM
Beside the measured number, compound 4's estimate is 10-fold (1.00 log units) below it; measured number outside the range, above it.
By their numbers in this assay, from the lowest: compounds 3, 1 and 2 (each within the scatter of the next); then compound 4.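

In this assay, this aromatic carbon proved sensitive to the identity of the halogen, even though fluoro and bromo there stay within the scatter of each other: chloro in place of fluoro gives a clear weakening (a 10-fold higher number from compound 1 to compound 4 (1.00 log units; beyond the scatter)), and so does chloro in place of bromo (a 9.5-fold higher number from compound 2 to compound 4 (0.98 log units; beyond the scatter)). The response across these three halogens is therefore not smooth, and the 4-chlorophenyl compound also lies well apart from the 3,4-dimethoxyphenyl compound (an 18-fold higher number from compound 3 to compound 4 (1.25 log units; beyond the scatter)). No measurement offered alongside these numbers accounts for this result.

The compounds shown leave open whether the weakening is peculiar to chloro or would also appear with iodo, methyl or an amine on the same carbon. They also leave open whether chloro would have the same effect on a ring carrying a second substituent.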